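This account rests on a few compounds, and the source may have more. Where it says the series, first, only, none or still open, it means among the compounds named here.

Notes on the series in a functional assay on IMR-32 cells (Homo sapiens) for antiproliferative activity, read by MTT assay; a higher number here means a weaker inhibitor, a lower number a stronger inhibitor. Compound 1 (`COc1ccc(-n2cc(COc3ccc(/C=C/C(=O)c4cc5c(cc4O)OC(C)(C)CC5)cc3)nn2)c([N+](=O)[O-])c1`) is reported as "not active" (no number reported). Compound 2 (`CCc1ccccc1-n1cc(COc2ccc(/C=C/C(=O)c3cc4c(cc3O)OC(C)(C)CC4)cc2)nn1`) is likewise reported as "not active" (no number reported). Within the data shown here, compound 3 (`CC1(C)CCc2cc(C(=O)/C=C/c3ccc(OCc4cn(Cc5ccc([N+](=O)[O-])cc5)nn4)cc3)c(O)cc2O1`) gives 108000 nM, the only number available, while the other two entries carry none, so it cannot be ranked against a second value and no step between measured compounds exists to scale from.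

Compound 4 (`CCCCCn1cc(COc2ccc(/C=C/C(=O)c3cc4c(cc3O)OC(C)(C)CC4)cc2)nn1`) is still unmeasured. Relative to compound 3 it shows (butyl in place of 4-nitrophenyl on a saturated chain carbon bound to an aromatic nitrogen). In words, this is butyl in place of 4-nitrophenyl on a saturated chain carbon bound to an aromatic nitrogen, or, cut one bond further out, 4-nitrobenzyl to pentyl.

Among the measured compounds shown here, the only anchor is compound 3 at 108000 nM, so no change beyond the scatter is expected, with a slight lean toward stronger inhibition. The expected move is a 1.5-fold lower number from compound 3 to compound 4 (0.19 log units; within the scatter). A report without a number also remains possible. For compound 4 the estimated value is 70000 nM, with an expected range of 20000 nM to 200000 nM.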

Compound 4, half-maximal inhibitory concentration: "not active" (no number reported)
No number was reported for compound 4; the estimate stays without a comparison.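

In this assay, among these compounds, compound 4 is reported as "not active" (no number reported), so no step from compound 3 can be read. No supporting data bear on this result. The compounds shown leave open how far butyl in place of 4-nitrophenyl moves the number.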